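Fluoro in place of methoxy at the assay limit

The source may report more compounds than this note shows. Statements on the series, on what has been measured and on what is new or still open speak of the compounds shown alone.

In a functional assay on KYSE-410 cells (Homo sapiens) for antiproliferative activity, read by MTT assay, with a stated time of 72 h (on this read-out lower numbers stand for stronger inhibition and higher numbers for weaker inhibition), compound 1 `O=C(Nc1ccc(Cl)cc1)c1ccnc2cc(Br)ccc12` gives > 20000 nM as a limit of the assay. Compound 2 `COc1ccc(NC(=O)c2cc(=O)[nH]c3cc(Br)ccc23)cc1` gives > 20000 nM as a limit too. Together the two form the limit of > 20000 nM in this assay, at which 2 of the 2 values shown sit, as the whole of the evidence. Compound 3 `O=C(Nc1ccc(F)cc1)c1cc(=O)[nH]c2cc(Br)ccc12` carries fluoro in place of methoxy on an aromatic carbon, para to a large group, counted as fluoro in place of methoxy on an aromatic carbon in full. No measured step sizes this change, and with compound 2 held at > 20000 nM as a limit no shift beyond the scatter is expected in this assay here. The step of a number no higher from compound 2 to compound 3 (the limit leaves the size open) is an expected one only. The estimate for compound 3 is 20000 nM within an estimated range of 6000 nM to 40000 nM overall.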

Compound 3, half-maximal inhibitory concentration: > 20000 nM
Compound 3: only a limit was reported; the forecaster's own chance of this, stated with the estimate: 70%; the middle value lies on the limit itself.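

No step can be read between compound 2 and compound 3, as both values are limits of the assay. The compounds shown leave open which change, if any, would bring a measurable value: the limit of > 20000 nM in this assay, at which 3 of the 3 values shown sit.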